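Working notes: from compound 3 to compound 4

A few compounds are considered here, and "the series" means these few. Any claim that something is new, unique, unknown or untested is made for them only; others in the source may bear on it.

Measured so far in a functional assay on CHO cells (Homo sapiens) for antiproliferative activity against CHO (Cricetulus griseus), read by sulforhodamine B assay, with a stated time of 48 h (a lower number here means a stronger inhibitor, a higher number a weaker inhibitor), as follows
- compound 1 `O=C1NCCN1c1ccc(S(=O)(=O)Nc2ccc3[nH]ccc3c2)cc1` gives 1310 nM
- compound 2 `COc1cc(NS(=O)(=O)c2ccc(N3CCNC3=O)cc2)cc(OC)c1OC` gives 190 nM
- compound 3 `O=C1NCCN1c1ccc(S(=O)(=O)Nc2cccc(Br)c2)cc1` gives 250 nM

In this assay compound 3 at 250 nM sits within the scatter of compound 2 at 190 nM and the two form a close pair. Compound 1 at 1310 nM lies beyond the scatter of compound 3 on the weaker side.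

Compound 4 `Cc1ccc(C)c(NS(=O)(=O)c2ccc(N3CCNC3=O)cc2)c1` has not yet been measured. The change from compound 3 is 2,5-dimethylphenyl in place of 3-bromophenyl on a sulfonamide nitrogen and in words it puts 2,5-dimethylphenyl in place of 3-bromophenyl on a sulfonamide nitrogen. Among the measured compounds shown here, no measured pair isolates this change, so the expectation rests only on the spread of the three values. Two of the three values sit close together, which favours a modest outcome, while compound 1 at 1310 nM argues for a wide range on the weaker side. The expected size is a 1.6-fold higher number from compound 3 to compound 4 (0.20 log units; within the scatter) and this estimated step points slightly towards weaker inhibition without leaving the scatter. Compound 4 is estimated to give 400 nM within a range of 120 nM to 1400 nM as the expected outcome.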

Compound 4, half-maximal inhibitory concentration: 77 nM
Beside the measured number, compound 4's estimate is 5.2-fold (0.72 log units) above it, and the stated range ends above it.
By their numbers in this assay, from the lowest: compound 4; then compounds 2 and 3 (each within the scatter of the next); then compound 1.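

Working notes after compound 4

In this assay, the group on a sulfonamide nitrogen is shown for the first time to affect the read-out in a single-place comparison: 2,5-dimethylphenyl in place of 3-bromophenyl gives a 3.2-fold lower number from compound 3 to compound 4 (0.51 log units; beyond the scatter). The change removes the only bromine and leaves the counts of hydrogen-bond donors, hydrogen-bond acceptors and net charge as they were, so bromine is not required on this aromatic ring for a low number in this pair. Nothing available bears on the reason for this step.

As far as these compounds go, this one step does not separate the contribution of the two methyl groups, so it remains open whether both are needed or whether either alone would give a similar number on the shared core. It also leaves open how this position responds to groups of a different kind, such as a methoxy group, an amine or a carboxylic acid on the phenyl ring, and whether a longer chain in place of the aromatic ring would be tolerated.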